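A few compounds are considered here, and "the series" means these few. Any claim that something is new, unique, unknown or untested is made for them only; others in the source may bear on it.

Compounds in hand:
compound 1 `CCCCCCCC/C=C/CCCCCCCC(=O)Nc1ccccc1CC`, 1200 nM in an assay on microsomes from intestine for inhibition of acyl-CoA:cholesterol acyltransferase (Oryctolagus cuniculus); on this read-out higher numbers stand for weaker inhibition and lower numbers for stronger inhibition
compound 2 `CCCCCCCC/C=C/CCCCCCCC(=O)Nc1ccccc1C(C)C`, 600 nM
compound 3 `CCCCCCCC/C=C/CCCCCCCC(=O)Nc1cccc(C)c1[N+](=O)[O-]`, 12000 nM

Compound 3 gives the highest number of the three; the step of a 10-fold higher number from compound 1 to compound 3 (1.00 log units; beyond the scatter) and the step of a 20-fold higher number from compound 2 to compound 3 (1.30 log units; beyond the scatter) both lie beyond the scatter, while a 2.0-fold lower number from compound 1 to compound 2 (0.30 log units; within the scatter) does not. Compound 4 `CCCCCCCC/C=C/CCCCCCCC(=O)Nc1c(C)cccc1OC` carries the change (2-methoxy-6-methylphenyl in place of 3-methyl-2-nitrophenyl on an amide-type nitrogen). The two steps that bear on it are those in which the 3-methyl-2-nitrophenyl group replaced an alkyl-bearing phenyl on the amide-type nitrogen, and both raised the number in this assay by a modest to large step. Reversing that exchange, back toward a phenyl with small substituents, is therefore expected to lower the number by about a 24-fold lower number from compound 3 to compound 4 (1.38 log units; beyond the scatter). Compound 4 is estimated at 500 nM, between 120 nM and 2500 nM.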

Compound 4, half-maximal inhibitory concentration: 20 nM
Compound 4: middle estimate off by 25-fold (1.40 log units), on the high side, outside the stated range (below it).
By their numbers in this assay, from the lowest: compound 4; then compounds 2 and 1 (each within the scatter of the next); then compound 3.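

On the amide-type nitrogen, 2-methoxy-6-methylphenyl does more in this assay than undo the loss seen with 3-methyl-2-nitrophenyl, giving a 600-fold lower number from compound 3 to compound 4 (2.78 log units; beyond the scatter). It also surpasses both alkyl-bearing phenyls, with a 30-fold lower number from compound 2 to compound 4 (1.48 log units; beyond the scatter) and a 60-fold lower number from compound 1 to compound 4 (1.78 log units; beyond the scatter), so the 2-ethylphenyl and 2-isopropylphenyl groups do not mark the best reach of this position. Nothing measured here accounts for the gain.

Open, going by these compounds, is whether the methoxy or the methyl carries the step, since the two enter together. Also open, on these data alone, is how an ethoxy in place of that methoxy would read.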